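Aryl urea series: second trifluoromethyl on the phenyl ring

The source may hold more compounds than are shown below. What is called first, only, known or untested is meant among the compounds shown, and "the series" means these compounds.

Measured compounds:
compound 1 `COc1cc(NC(C)CCCNC(=O)NNC(=O)Nc2ccc(Br)cc2)c2ncccc2c1` 51000 nM
compound 2 `COc1cc(NC(C)CCCNC(=O)Nc2cccc(C(F)(F)F)c2)c2ncccc2c1` 9200 nM

In a functional assay on L1210 cells (Mus musculus) for inhibition, read by MTT assay, with a stated time of 72 h (on this read-out lower numbers stand for stronger inhibition and higher numbers for weaker inhibition), compound 2 gives 9200 nM, the lowest of the two numbers; its nearest neighbour is compound 1 with 51000 nM. Going by the values given here, the one measured step, a 5.5-fold lower number from compound 1 to compound 2 (0.74 log units; beyond the scatter), replaces the whole terminal arm and is modest in size. Compound 3 `COc1cc(NC(C)CCCNC(=O)Nc2cc(C(F)(F)F)cc(C(F)(F)F)c2)c2ncccc2c1` differs from compound 2 only at the aryl ring: trifluoromethyl in place of hydrogen on an aromatic carbon. Among the compounds with values here, no measured step adds a group to this ring, so the one step bears on it only loosely, as a sign that changes at this end of the chain move this assay by a modest amount. A change no larger than that, with no clear direction, is expected, and a step of a 1.3-fold lower number from compound 2 to compound 3 (0.12 log units; within the scatter) is the estimate. For compound 3 the expected value in this assay is 7000 nM, within 2500 nM to 20000 nM.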

Compound 3, half-maximal inhibitory concentration: 3500 nM
Beside the measured number, compound 3's estimate is 2.0-fold (0.30 log units) above it; the measured number falls inside the stated range.
By their numbers in this assay, from the lowest: compound 3; then compound 2; then compound 1.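

In this assay, trifluoromethyl in place of hydrogen on an aromatic carbon gives a 2.6-fold lower number from compound 2 to compound 3 (0.42 log units; beyond the scatter). Going by these compounds alone, this is the first step confined to the aryl ring, whereas the earlier step replaced the whole terminal arm, and it shows that a single added group on this ring can move the number beyond the scatter, here towards stronger inhibition. No supporting measurement bears on the reason for this modest step.

Whether the lower number is particular to trifluoromethyl at this aromatic carbon remains open, as the compounds shown do not tell how chlorine, a methoxy group or an amine would behave there. Also open, going by these compounds, is whether a longer chain between the shared core and the urea would change the effect of the second trifluoromethyl.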